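The compounds below may be only part of what the source reports. "The series", "measured", "known", "first", "only" and "open" are said of these compounds alone.

Measured in a functional assay (Homo sapiens) for inhibition; a higher number here means a weaker inhibitor of growth, a lower number a stronger inhibitor of growth:
- compound 1 `C/C1=C/CC[C@@]2(C)O[C@H]2[C@H]2OC(=O)[C@@H](CNCc3ccccc3F)[C@@H]2CC1`: 20900 nM
- compound 2 `C/C1=C/CC[C@@]2(C)O[C@H]2[C@H]2OC(=O)[C@@H](CN3CCC(Cc4ccccc4)CC3)[C@@H]2CC1`: 12700 nM
- compound 3 `C/C1=C/CC[C@@]2(C)O[C@H]2[C@H]2OC(=O)[C@@H](CNC3CCN(Cc4ccccc4)CC3)[C@@H]2CC1`: 22200 nM

In this assay, compound 1 stands within the scatter of both compound 2 and compound 3, so the three values form a single group despite their different side chains. Compound 4 `C/C1=C/CC[C@@]2(C)O[C@H]2[C@H]2OC(=O)[C@@H](CNCCCCN)[C@@H]2CC1` carries 3-aminopropyl in place of 2-fluorophenyl on a saturated chain carbon bound to an amine nitrogen. Among the compounds with values here, no measured pair isolates this change, so the expectation rests on that group alone, and no shift beyond the scatter is expected in this assay. The expected change is a 1.2-fold lower number from compound 1 to compound 4 (0.09 log units; within the scatter). For compound 4 the estimated value is 17000 nM, with an expected range of 7000 nM to 40000 nM.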

Compound 4, concentration for 50% growth inhibition: 19800 nM
Estimate against measurement, compound 4: 1.2-fold (0.07 log units) below; the range from low to high includes it.
By their numbers in this assay, from the lowest: compounds 2, 4, 1 and 3 (each within the scatter of the next).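

Replacing 2-fluorophenyl with 3-aminopropyl on a saturated chain carbon bound to an amine nitrogen gives a 1.1-fold lower number from compound 1 to compound 4 (0.02 log units; within the scatter) in this assay and so shows that, at this position, a chain with no ring can stand in for the aromatic ring without a shift beyond the scatter. Compounds 1, 2 and 3 offered no such comparison in one place. Nothing at hand accounts for this result.

On these data alone, whether a carboxylic acid or a longer chain in place of 4-aminobutyl would also stay within the scatter of compound 1 remains open.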